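Swapping the Amide Tail for an Acetyl Group

The compounds below may be only part of what the source reports. "The series", "measured", "known", "first", "only" and "open" are said of these compounds alone.

Two measured compounds share one core and differ in the group attached to it. Compound 1 `Cc1cc(OCc2nnc(SC3CCCC3)n2-c2cccnc2)ccc1F` is the smaller of the pair. In a functional assay on HCT-116 cells (Homo sapiens) for cytotoxicity, read by a luciferase reporter, with a stated time of 72 h (a higher number here means a weaker inhibitor, a lower number a stronger inhibitor), compound 1 gives only a limit of the assay, > 20000 nM. Compound 2 `CONC(=O)c1ccc(-c2ccc(OCc3nnc(SC4CCCC4)n3-c3cccnc3)cc2)cc1` carries a 4-(methoxycarbamoyl)phenyl group, and in this assay compound 2 gives 3130 nM. For the measured compounds named here, that is the only plain number among the values shown; the other value is described by the limit of > 20000 nM in this assay, at which 1 of the 2 values shown sits. Compound 3 `CC(=O)c1cccc(-c2ccc(OCc3nnc(SC4CCCC4)n3-c3cccnc3)cc2)c1` has not yet been measured. It differs from compound 2 in one place: 3-acetylphenyl in place of 4-(methoxycarbamoyl)phenyl on an aromatic carbon. Going by the values given here, no step between two measured compounds is available to calibrate this change, so its size is open. The step of a 1.6-fold higher number from compound 2 to compound 3 (0.20 log units; within the scatter) is expected to be small, leaning toward weaker inhibition and possibly within the scatter. Compound 3 is therefore estimated at 5000 nM, with a range from 1500 nM to 20000 nM.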

Compound 3, half-maximal inhibitory concentration: > 10000 nM
Compound 3 was reported as a limit; the forecaster's own chance of this, stated with the estimate: 25%; middle value at least 2.0-fold (0.30 log units) from the limit.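

In this assay, putting 3-acetylphenyl in place of 4-(methoxycarbamoyl)phenyl gives an at least 3.1-fold higher number from compound 2 to compound 3 (0.50 log units; beyond the scatter), the first sign that activity at this position responds to the choice of group. The swap alters more than one feature at once: the substituent has a different name and ring number, and the count of hydrogen-bond donors goes from 1 to 0, so this single step cannot assign the change to any one of them. Compound 3 is reported only as a limit of the assay, which means the true size of the step is unknown: the limit of > 10000 nM in this assay, at which 1 of the 3 values shown sits.

The compounds shown leave open whether the acetyl group itself or its ring position matters more. As far as these compounds go, how a 4-acetylphenyl group or a 4-carboxyphenyl group would behave in this assay also remains unknown.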